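Swapping a Methoxyphenyl for Pyridyl on a Nitrile Core

The source may report more compounds than this note shows. Statements on the series, on what has been measured and on what is new or still open speak of the compounds shown alone.

Compound 1, `COc1cccc(-c2cc(-c3ccc(F)cc3)c(C#N)c(OC)n2)c1`: 108 nM
Compound 2, `COc1nc(-c2ccccc2)cc(-c2ccc(Cl)cc2Cl)c1C#N`: > 100000 nM

For the measured compounds named here, in an assay on isolated protein for inhibition of sulfide:quinone oxidoreductase, mitochondrial (Homo sapiens) (a higher number here means a weaker inhibitor, a lower number a stronger inhibitor), compound 1 gives 108 nM, the only true number among the two measured compounds. Compound 2 gives > 100000 nM, which is a limit of the assay rather than a number. Compound 2 sits at the limit of > 100000 nM in this assay, at which 1 of the 2 values shown sits. Compound 2 also differs from compound 1 in more than one place, so no single step can be read from that pair.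

Compound 3 is `COc1nc(-c2ccncc2)cc(-c2ccc(F)cc2)c1C#N`. Compared with compound 1 it carries pyridin-4-yl in place of 3-methoxyphenyl on an aromatic carbon, placed next to the ring nitrogen of the shared core. Going by the values given here, no step between measured compounds exists here, and the expectation for compound 3 rests on the structural change alone. A modest weakening in this assay is expected, a 3.2-fold higher number from compound 1 to compound 3 (0.51 log units; beyond the scatter), beyond the usual scatter but not large. Compound 3 is expected to give about 350 nM, with a range from 80 nM to 1500 nM.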

Compound 3, half-maximal inhibitory concentration: 17400 nM
For compound 3 the middle estimate is 50-fold (1.70 log units) below the measured one, outside the stated range (above it).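

For the compounds shown here, this place is far from indifferent: putting pyridin-4-yl where 3-methoxyphenyl stood gives a 160-fold higher number from compound 1 to compound 3 (2.21 log units; beyond the scatter) in this assay and is the first single change that can be read here. The place, next to the ring nitrogen of the shared core, responds strongly to what sits on it, even though the entering and leaving groups each count one hydrogen-bond acceptor and compound 3 still gives 17400 nM as a true number. Nothing shown here accounts for the size of this step.

The swap changes two things at once, as the methoxy group leaves and a ring nitrogen enters, and the compounds shown do not separate the two. Going by these compounds, whether a 3-aminophenyl or 3-ethoxyphenyl group at this place would match compound 1 stays open.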